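Trifluoromethoxy for nitro on a urea-linked aryl ring

A few compounds are considered here, and "the series" means these few. Any claim that something is new, unique, unknown or untested is made for them only; others in the source may bear on it.

Compound 1, `CC1(C)CCNc2ccc(NC(=O)Nc3ccc([N+](=O)[O-])cc3)cc21`, in an assay on isolated protein for binding affinity to stress-70 protein, mitochondrial (Homo sapiens) (a lower number here means tighter binding, a higher number weaker binding), gives 1100 nM.
Compound 2, `CN1c2ccc(NC(=O)Nc3ccc(N)cc3)cc2C(C)(C)C(=O)C1(C)C`, in this assay gives 1100 nM.
Compound 3, `CN1c2ccc(NC(=O)Nc3ccc([N+](=O)[O-])cc3)cc2C(C)(C)C(O)C1(C)C`, in this assay gives 1600 nM.

All three measured compounds share a urea bridge to an aryl ring and a bicyclic core bearing gem-dimethyl groups. In this assay compound 3 carries a number that is close to those of compound 1 and compound 2, the gaps to either lying within the scatter of repeated measurements, so no order among the three can be read from these values.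

Compound 4, `CN1c2ccc(NC(=O)Nc3ccc(OC(F)(F)F)cc3)cc2C(C)(C)C(O)C1(C)C`, keeps the core of compound 3 with its hydroxyl and methylated nitrogen and differs only on the distal aryl ring: trifluoromethoxy in place of nitro on an aromatic carbon. Among the compounds with values here, no pair of measured compounds isolates this exchange, so its size is not known from the data given here. The aryl substituents seen so far, nitro and amino, give numbers within the scatter of one another, which suggests this position tolerates varied groups. Compound 4 is therefore expected to land near compound 3, at 1500 nM, with a plausible range from 500 nM to 4500 nM, the expected step of a 1.1-fold lower number from compound 3 to compound 4 (0.03 log units; within the scatter) being no larger than the scatter.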

Compound 4, dissociation constant: 1100 nM
For compound 4 the middle estimate is 1.4-fold (0.13 log units) above the measured one; measured number inside the range.
By their numbers in this assay, from the lowest: compounds 1, 2, 4 and 3 (each within the scatter of the next).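

In this assay, within the data shown here, trifluoromethoxy in place of nitro on an aromatic carbon, para to a large group, gives a 1.5-fold lower number from compound 3 to compound 4 (0.16 log units; within the scatter) and so gives this exchange a size, which the earlier compounds, differing in more than one place, could not. On the core of compound 3, this position therefore accepts either group with no difference that can be read beyond the scatter. No measurement shown here accounts for this result.

The compounds shown leave open whether a carboxylic acid or a longer chain such as butoxy on the same aromatic carbon would stay within the scatter of compound 3. They also leave open whether trifluoromethoxy in place of nitro would give a similar step on the core of compound 1.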